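Swapping a Nitro for an Oxazole: Will Cytotoxicity Change?

This account rests on a few compounds, and the source may have more. Where it says the series, first, only, none or still open, it means among the compounds named here.

Compound 1 `O=C(Nc1cccc(Oc2ccccn2)c1)C1CCCN(C(=O)c2cc(C(F)(F)F)cc(C(F)(F)F)c2)C1` was tested in an ADME assay on PC-3 cells (Homo sapiens) for cytotoxicity, read by WST assay, tested at 100 uM (on this read-out lower numbers stand for less inhibition and higher numbers for more inhibition at the one concentration tested (going by the name of the read-out)), and gave a reading of 0%, which means the cells were essentially unaffected at the single concentration used. Compound 2 `O=C(Nc1ccc(Cl)cc1)C1CCCN(C(=O)c2cccc([N+](=O)[O-])c2)C1` shares the same core but carries a chloro-substituted aniline and a nitro group on the benzoyl ring; in this assay compound 2 gives 0%. Compound 2 therefore stands level with compound 1 at the digits shown, and the two readings are within the usual scatter of each other, so nothing separates them.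

Compound 3 `O=C(Nc1ccc(Cl)cc1)C1CCCN(C(=O)c2cccc(-c3cnco3)c2)C1` has not been measured. It differs from compound 2 at one place: 1,3-oxazol-5-yl in place of nitro on an aromatic carbon. Among the compounds with values here, neither measured compound shows any cell-killing effect, and no step between measured compounds exists here to show how a change at this place moves the reading in this assay. The expectation is that compound 3 will also sit at the bottom of the scale, with no step beyond the scatter. Compound 3 is therefore estimated at 0%, within a range from 0% to 12%. The step this estimate implies, no change at the digits printed from compound 2 to compound 3 (within the scatter), is expected to be nothing beyond the scatter.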

Compound 3, a percentage reported as inhibition, at one concentration (the size of the read-out at that concentration, not a potency): 0%
Beside the measured number, compound 3's estimate shows no gap at the digits printed; low and high end bracket the measured number.
By their numbers in this assay, from the lowest: compounds 1, 2 and 3 (each within the scatter of the next).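

In this assay, within the data shown here, placing 1,3-oxazol-5-yl instead of nitro on the aromatic carbon gives no change at the digits printed from compound 2 to compound 3 (within the scatter), and this is the first step here that isolates a single change at this position. It shows that a group with a five-membered aromatic ring can take the place of nitro on this compound without any inhibition appearing in this assay at the one concentration tested. No supporting measurement is available to explain this reading.

Among these compounds, with both compounds at the bottom of the scale, the step can show only that neither group produces a reading in this assay, not how far a group at this position could move the result in either direction. Going by these compounds, it remains open whether an amine, a carboxylic acid or a longer chain in this place would also leave the reading unchanged, or whether one of them would bring out inhibition.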